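Benzamide series: chloro to hydrogen on the benzoyl

This account rests on a few compounds, and the source may have more. Where it says the series, first, only, none or still open, it means among the compounds named here.

Measured so far:
compound 1 `COc1ccc(CNC(=O)CSc2nc3ccc(NC(=O)c4ccc(Cl)cc4)cc3s2)cc1` — 19200 nM
compound 2 `O=C(CSc1nc2ccc(NC(=O)c3ccc(Cl)cc3)cc2s1)NCc1ccc(Cl)cc1` — 29300 nM

In a functional assay on MCF7 cells (Homo sapiens) for cytotoxicity, read by MTT assay, with a stated time of 48 h (a lower number here means a stronger inhibitor, a higher number a weaker inhibitor), compound 1 gives 19200 nM and compound 2 gives 29300 nM. Compound 2 carries the higher number of the two, yet the step of a 1.5-fold higher number from compound 1 to compound 2 (0.18 log units; within the scatter) lies within the scatter, so on this read-out the two compounds cannot be told apart.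

Compound 3 `O=C(CSc1nc2ccc(NC(=O)c3ccccc3)cc2s1)NCc1ccc(Cl)cc1` has not yet been measured. It differs from compound 2 in one place: hydrogen in place of chloro on an aromatic carbon. Read one bond further out, the same difference is 4-chlorophenyl to phenyl, or ((4-chlorophenyl)carbonyl)amino to benzamido.

Within the data shown here, no measured step touches this part of the molecule. Among the measured compounds shown here, the only step in hand, a 1.5-fold higher number from compound 1 to compound 2 (0.18 log units; within the scatter), sits elsewhere and was within the scatter. Nothing in the numbers therefore points in either direction, and the expected step of a 1.0-fold higher number from compound 2 to compound 3 (0.01 log units; within the scatter) is none beyond the scatter. Compound 3 is accordingly estimated at 30000 nM in this assay, with a range from 12000 nM to 75000 nM.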

Compound 3, half-maximal inhibitory concentration: 33700 nM
For compound 3 the middle estimate is 1.1-fold (0.05 log units) below the measured one, and the stated range covers the measured number.
By their numbers in this assay, from the lowest: compounds 1, 2 and 3 (each within the scatter of the next).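

In this assay, among these compounds, the first reading at this position is a 1.2-fold higher number from compound 2 to compound 3 (0.06 log units; within the scatter) and so 4-chlorophenyl and phenyl cannot be told apart here, which means the chloro para to a large group is not needed for a reading of this size in this pair. Taken with a 1.5-fold higher number from compound 1 to compound 2 (0.18 log units; within the scatter) as the only other single-place step, two separate places have now been varied and neither step lies beyond the scatter, a statement that holds for compounds 1, 2 and 3 only. No available measurement accounts for these readings.

Still open, from the compounds shown here alone, is whether any group on the benzoyl ring moves the number beyond the scatter, for instance an amine, a carboxylic acid or a nitrile at the carbon that carries the chloro in compound 2. Also open, going by these compounds, is whether the phenyl of compound 3 reads the same when the remaining chloro gives way to the methoxy of compound 1, and whether a longer chain between the core and the amide alters the picture.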